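Trimming a Branched Alkyl Group in a Weakly Active Urea Series

This account rests on a few compounds, and the source may have more. Where it says the series, first, only, none or still open, it means among the compounds named here.

Measured compounds:
Compound 1 `Cc1ccc(N2CCN(C(=O)Nc3ccc(C(C)C)cc3)CC2)nn1` gives > 10000 nM in an assay on HEK293 cells for inhibition of transient receptor potential cation channel subfamily V member 1 (Homo sapiens), read by FLIPR, at pH 5.5; on this read-out higher numbers stand for weaker inhibition and lower numbers for stronger inhibition.
Compound 2 `O=C(Nc1ccc(OC(F)(F)F)cc1)N1CCN(c2ccc(-c3ccccc3)nn2)CC1` gives > 10000 nM in this assay.
Compound 3 `CC(C)(C)c1ccc(NC(=O)N2CCN(c3nncc4ccccc34)CC2)cc1` gives > 10000 nM in this assay.

Each of these three values is a limit of the assay, not a number. For compound 3 the read-out stopped at the limit of > 10000 nM in this assay, at which 3 of the 3 values shown sit, so its true potency is only known to lie beyond that point. Compound 4 `CC(C)c1ccc(NC(=O)N2CCN(c3nncc4ccccc34)CC2)cc1` differs from compound 3 by hydrogen in place of methyl on a saturated chain carbon bound to an aromatic carbon and two saturated chain carbons. Going by the values given here, no step between measured compounds is available to size this change, and the three measured compounds offer no spread to lean on. The step from compound 3 to compound 4 in this assay is expected to be small, a step that the limit leaves unreadable from compound 3 to compound 4, without a clear direction. Compound 4 is therefore estimated at 15000 nM, most likely again beyond the assay limit, between 5000 nM and 50000 nM.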

Compound 4, half-maximal inhibitory concentration: > 10000 nM
Compound 4: only a limit was reported; the forecaster's own chance of this, stated with the estimate: 80%; the middle value does not contradict the limit.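

Compound 3 and compound 4 both sit at a limit rather than at a number, so the change from tert-butyl to isopropyl gives no readable step: the limit of > 10000 nM in this assay, at which 4 of the 4 values shown sit.

The compounds shown leave open whether this change matters at all, and whether any urea of this kind gives a true number.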